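Cytotoxicity notes: compound 2 to compound 3

The source may report more compounds than this note shows. Statements on the series, on what has been measured and on what is new or still open speak of the compounds shown alone.

Compound 1 `O=S(=NSC(F)(F)F)(c1ccccc1)N1CCOCC1` has no result reported in a functional assay on HepG2 cells (Homo sapiens) for cytotoxicity, read by spectrophotometry, with a stated time of 6 h (on this read-out lower numbers stand for higher toxicity in this test and higher numbers for lower toxicity in this test), where compound 1 stands as "not determined" (no result reported). Going by the values given here, compound 2 `O=S(=NSC(F)(F)F)(c1ccccc1)N1CCCC1` gives 0.1 ug/mL in this assay, the only number so far, with no second value to set beside it. Compound 3 `CS(=O)(=NSC(F)(F)F)c1ccccc1` differs from compound 2 in one place: methyl in place of pyrrolidin-1-yl on a sulfinyl sulfur. Among the compounds with values here, no measured step is available for this change, so the size of the move is open; a modest shift toward a higher number, not far beyond the scatter, is expected, a 3.0-fold higher number from compound 2 to compound 3 (0.48 log units; beyond the scatter). For compound 3 the estimated result is 0.3 ug/mL, with a range from 0.05 ug/mL to 3 ug/mL.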

Compound 3, minimum cytotoxic concentration: 0.1 ug/mL
Estimate against measurement, compound 3: 3.0-fold (0.48 log units) above; low and high end bracket the measured number.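

In this assay, going by these compounds alone, methyl in place of pyrrolidin-1-yl on a sulfinyl sulfur gives no change at the digits printed from compound 2 to compound 3 (within the scatter) and provides the first readable comparison at this position. On this single step, the five-membered ring is not required for the reading seen with compound 2, and a single methyl carbon suffices. No supporting data bear on why the reading holds across this change. On these data alone, whether a longer alkyl chain, a primary amine or a carboxylic acid on the same sulfur would keep this reading remains open. One step also cannot show whether the same holds on other cores.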